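Swapping the Aryl Ring on a Bromophenyl Enone Sulfone

A few compounds are considered here, and "the series" means these few. Any claim that something is new, unique, unknown or untested is made for them only; others in the source may bear on it.

Measured so far:
compound 1, `O=C(/C(=C\c1ccc(Cl)c([N+](=O)[O-])c1)S(=O)(=O)c1ccc(Br)cc1)c1ccc(Br)cc1`: 10000 nM
compound 2, `O=C(/C(=C\c1ccc(Cl)c([N+](=O)[O-])c1)Sc1ccc(Br)cc1)c1ccc(Br)cc1`: 10000 nM

In a functional assay on DU-145 cells (Homo sapiens) for inhibition, read by trypan blue exclusion, with a stated time of 96 h (a higher number here means a weaker inhibitor of growth, a lower number a stronger inhibitor of growth), compound 1 gives 10000 nM. In this assay compound 2 gives 10000 nM. Among the compounds with values here, the one measured step, no change at the digits printed from compound 1 to compound 2 (within the scatter), shows that exchanging the sulfur-linked group on the shared core left the read-out unchanged within the scatter, so compound 1 stands level with compound 2 and is neither the stronger nor the weaker of the pair.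

Compound 3, `COc1ccc(/C=C(\C(=O)c2ccc(Br)cc2)S(=O)(=O)c2ccc(Br)cc2)c(OC)c1`, differs from compound 1 by 2,4-dimethoxyphenyl in place of 4-chloro-3-nitrophenyl on a double-bonded chain carbon bound to a double-bonded chain carbon. Within the data shown here, no measured step touches this ring: the step from compound 1 to compound 2 concerns the sulfur-linked group, not the aryl ring on the double-bonded chain carbon, and so gives no direct guide. Both measured compounds sit at the same value, and nothing in the data points to a change in either direction.

Compound 3 is therefore expected to give about 10000 nM in this assay, with a range from 3000 nM to 30000 nM. The expected step of no change at the digits printed from compound 1 to compound 3 (within the scatter) is estimated to lie within the scatter.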

Compound 3, concentration for 50% growth inhibition: 8000 nM
Beside the measured number, compound 3's estimate is 1.3-fold (0.10 log units) above it; the measured number falls inside the stated range.
By their numbers in this assay, from the lowest: compounds 3, 1 and 2 (each within the scatter of the next).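

In this assay, 2,4-dimethoxyphenyl in place of 4-chloro-3-nitrophenyl on a double-bonded chain carbon bound to a double-bonded chain carbon gives a 1.3-fold lower number from compound 1 to compound 3 (0.10 log units; within the scatter). Within the data shown here, this is the first reading at this position, and it shows that the two methoxy groups can take over from the chloro and nitro pair on this ring with the read-out staying within the scatter, whereas the earlier pair spoke only to the sulfur-linked group. No supporting data bear on why the read-out holds across this exchange.

The compounds shown leave open whether a ring carrying an amine or a carboxylic acid at this place would move the number beyond the scatter. They also leave open whether the sulfanyl link of compound 2 would read the same alongside 2,4-dimethoxyphenyl.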